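Methoxy for Methyl on the Weaker of Two Binders

The source may hold more compounds than are shown below. What is called first, only, known or untested is meant among the compounds shown, and "the series" means these compounds.

Compound 1 `CCCN(CCC)c1cc(C)nc2c(-c3ccc(C#N)cc3)c(C)nn12`: 3.5 nM
Compound 2 `CCCN(CCC)c1cc(CC)nc2c(-c3ccc(Cl)cc3)c(C)nn12`: 100 nM

Of the compounds shown here, two have been measured in an assay on isolated protein for binding affinity to corticotropin-releasing factor receptor 1 (Homo sapiens); a higher number here means a weaker inhibitor, a lower number a stronger inhibitor. Compound 1 gives 3.5 nM in this assay, and compound 2 gives 100 nM. Among the measured compounds shown here, compound 2 therefore stands with the higher of the two numbers; its only neighbour is compound 1, whose number lies far lower, a gap beyond the scatter. The two structures differ in more than one place, so that gap cannot be tied to any single change.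

Compound 3 `CCCN(CCC)c1cc(COC)nc2c(-c3ccc(Cl)cc3)c(C)nn12` differs from compound 2 in one place: methoxy in place of methyl on a saturated chain carbon bound to an aromatic carbon. For the measured compounds named here, no measured pair shows this change, so its effect in this assay is unknown from the data at hand. Compound 3 is expected to land somewhat lower than compound 2, a step of a 2.2-fold lower number from compound 2 to compound 3 (0.35 log units; beyond the scatter) that may not clear the scatter. Compound 3 is estimated at 45 nM, within 12 nM to 180 nM.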

Compound 3, inhibition constant: > 10000 nM
Compound 3: no number, only a limit (the forecaster's own chance of this, stated with the estimate: 2%); middle value at least 220-fold (2.34 log units) away from the limit.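

Replacing methyl with methoxy at this place, on a saturated chain carbon bound to an aromatic carbon, gives an at least 100-fold higher number from compound 2 to compound 3 (2.00 log units; beyond the scatter) in this assay. Among the compounds shown here, this is the first change that can be read on its own, and it shows that going from ethyl to methoxymethyl at this place is far from neutral. Compound 3 has no number here, only a limit of the assay: the limit of > 10000 nM in this assay, at which 1 of the 3 values shown sits.

Going by these compounds, how far past that limit compound 3 lies stays unknown, so the step has a lower bound but no fixed size. The compounds shown also do not separate the oxygen from the added chain length, a question that a propyl group, a hydroxymethyl group or an amine at this place would bear on, and they leave open whether methoxy would act alike on the nitrile-bearing compound 1.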